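The compounds below may be only part of what the source reports. "The series", "measured", "known", "first", "only" and "open" are said of these compounds alone.

Compound 1 `O=C(Nc1ccc(Sc2nc3ccccc3s2)c(Cl)c1)c1cccc(Br)c1O`: 64000 nM
Compound 2 `O=C(Nc1ccc(Sc2nc3ccccc3s2)cc1)c1ccccc1O`: 74000 nM

In an ADME assay on HEK293 cells (Homo sapiens) for cytotoxicity, read by reporter gene assay and resazurin assay, with a stated time of 48 h (on this read-out lower numbers stand for higher toxicity in this test and higher numbers for lower toxicity in this test), compound 1 gives 64000 nM and compound 2 gives 74000 nM, two numbers within the usual scatter of each other. For the measured compounds named here, compound 1 therefore stands level with the only other measured compound, and neither can be ranked above the other.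

Compound 3 `O=C(Nc1ccc(Sc2nc3ccccc3s2)c(Cl)c1)c1cc(Br)cc(Br)c1O` is reached from compound 1 by a single change: bromo in place of hydrogen on an aromatic carbon. The 3-bromo-2-hydroxyphenyl group thus becomes 3,5-dibromo-2-hydroxyphenyl, with the new bromo para to a hydroxy group. Going by the values given here, no measured pair differs in one place, so the data give no direct size for such a step. A modest move toward higher toxicity is expected, and it may not clear the scatter. The expected change is an estimated 1.6-fold lower number from compound 1 to compound 3 (0.20 log units; within the scatter). For compound 3 the estimated value is 40000 nM, with an expected range of 14000 nM to 100000 nM.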

Compound 3, half-maximal cytotoxic concentration: 76000 nM
The estimate for compound 3 lay 1.9-fold (0.28 log units) below the measured number, and the stated range covers the measured number.
By their numbers in this assay, from the lowest: compounds 1, 2 and 3 (each within the scatter of the next).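

In this assay, bromo in place of hydrogen on an aromatic carbon, para to a hydroxy group, gives a 1.2-fold higher number from compound 1 to compound 3 (0.07 log units; within the scatter) and so stays within the scatter. This is the first step in one place among these compounds, and it shows that going from 3-bromo-2-hydroxyphenyl to 3,5-dibromo-2-hydroxyphenyl leaves compound 3 level with compound 1 on this read-out, with no sign of a shift toward higher toxicity in this test. Nothing measured here bears on why the two numbers stand level.

Whether an amine or a carboxylic acid at this same position would also stay level remains open, since bromo is the only group shown there. For the compounds shown here, the separate contributions of the chloro group and the first bromo group of compound 1 also remain open, since compound 2 differs from it in both places at once.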